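The compounds below may be only part of what the source reports. "The series", "measured", "known", "first", "only" and "open" are said of these compounds alone.

Compound 3, `Fc1ccc(-c2cn3ccnc3c(-c3ccc4ncn(C5CCCCC5)c4c3)n2)cc1`, stands second highest of the three numbers in a functional assay on BT-549 cells (Homo sapiens) for inhibition, read by sulforhodamine B assay, with a stated time of 48 h, tested at 10 uM (on this read-out lower numbers stand for less inhibition and higher numbers for more inhibition at the one concentration tested (going by the name of the read-out)), where compound 3 gives 20.3%. Compound 1, `Brc1cn2ccnc2c(-c2ccc3ncn(C4CCCCC4)c3c2)n1`, gives 5.16% in this assay, and compound 2, `O=Cc1ccc(-c2cn3ccnc3c(-c3ccc4ncn(C5CCCCC5)c4c3)n2)cc1`, gives 33.8%. The measured steps are a number 15.1 percentage points higher from compound 1 to compound 3 (beyond the scatter), a number 28.6 percentage points higher from compound 1 to compound 2 (beyond the scatter) and a number 13.5 percentage points lower from compound 2 to compound 3 (beyond the scatter); each swaps one group for another. Compound 4, `Fc1ccccc1-c1cn2ccnc2c(-c2ccc3ncn(C4CCCCC4)c3c2)n1`, differs from compound 3 by 2-fluorophenyl in place of 4-fluorophenyl on an aromatic carbon, the same atoms joined differently. For the measured compounds named here, no measured step alters the point at which fluorine sits on the phenyl ring, so none bears directly on this change. The estimate for compound 4 is therefore 20%, between 8% and 34%, an expected step of a number 0.3 percentage points lower from compound 3 to compound 4 (within the scatter) that lies within the scatter.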

Compound 4, a percentage reported as inhibition, at one concentration (the size of the read-out at that concentration, not a potency): 4.08%
Compound 4: middle estimate off by 15.9 percentage points, on the high side; the measured number lies below the stated range.
By their numbers in this assay, from the lowest: compounds 4 and 1 (each within the scatter of the next); then compound 3; then compound 2.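

In this assay, the placing of the fluorine on the phenyl ring counts: 2-fluorophenyl in place of 4-fluorophenyl gives a number 16.2 percentage points lower from compound 3 to compound 4 (beyond the scatter), although the two groups hold the same atoms. An aryl group at this place therefore does not by itself lift the number, since the 2-fluorophenyl compound shows a number 29.7 percentage points lower from compound 2 to compound 4 (beyond the scatter) and a number 1.1 percentage points lower from compound 1 to compound 4 (within the scatter) against the bromo compound. No measured evidence here accounts for this difference. Going by these compounds, whether a phenyl ring carrying an amine or a carboxylic acid would reach the number of compound 2 remains open.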